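The compounds below may be only part of what the source reports. "The series", "measured", "known", "first", "only" and "open" are said of these compounds alone.

Measured so far:
compound 1 `O=C(CCCCCCc1ccccc1F)N1CCCC1` — 13700 nM
compound 2 `Cc1ccccc1-c1ccc(CCC(=O)N2CCCC2)cc1` — > 100000 nM

In an assay on HEK293 cells for inhibition of N-acylethanolamine-hydrolyzing acid amidase (Rattus norvegicus), read by LC-MS, with a stated time of 30 min (a higher number here means a weaker inhibitor, a lower number a stronger inhibitor), compound 1 gives 13700 nM. Compound 2 reaches only the limit of this assay, > 100000 nM, and no number; it is one of the two values on the line (the limit of > 100000 nM in this assay, at which 1 of the 2 values shown sits). Compound 3 `O=C(CCc1ccc(-c2ccccc2F)cc1)N1CCCC1` differs from compound 2 by fluoro in place of methyl on an aromatic carbon. Among the measured compounds shown here, no measured pair shows this change, so no step beyond the usual scatter is expected; the estimated step is an at least 1.2-fold lower number from compound 2 to compound 3 (0.09 log units; that floor lies within the scatter). Compound 3 is expected at 80000 nM, between 20000 nM and 300000 nM, with a fair chance that again only a limit is reported.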

Compound 3, half-maximal inhibitory concentration: 2800 nM
Compound 3: middle estimate off by 29-fold (1.46 log units), on the high side; measured number outside the range, below it.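

In this assay, fluoro in place of methyl on an aromatic carbon, ortho to a large group, gives an at least 35-fold lower number from compound 2 to compound 3 (1.55 log units; beyond the scatter). This single-atom change at this position therefore separates a compound with a measurable number from one without. Compound 2 gives only a limit of the assay, > 100000 nM, so the step has a floor and no upper bound.

From the compounds shown here alone, it remains open whether the drop follows from fluoro entering or from methyl leaving. Going by these compounds, the readings of chloro or methoxy at this position, and of the same change on a longer chain, also remain open.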